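A Chloro Group Added to the Anilide of Compound 1

A few compounds are considered here, and "the series" means these few. Any claim that something is new, unique, unknown or untested is made for them only; others in the source may bear on it.

Compound 1 `CCn1c(CNc2ccccc2)nnc1SCC(=O)Nc1ccccc1` was examined in an assay on isolated protein for inhibition of long-chain fatty acid transport protein 1 (Homo sapiens); a lower number here means a stronger inhibitor, a higher number a weaker inhibitor. In this assay compound 1 gives > 1000 nM, which is a limit of the assay and not a number. A second compound built on a different core, compound 2 `CCC(=O)c1ccc2oc(CS(=O)(=O)c3nnc(CNc4ccccc4)n3CC)nc2c1`, was measured as well; in this assay compound 2 gives 1670 nM. For the measured compounds named here, no step between these two is given, and their values show only that compound 2 yields a number while compound 1 sits at the limit of > 1000 nM in this assay, at which 1 of the 2 values shown sits.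

The unmeasured compound 3 `CCn1c(CNc2ccccc2)nnc1SCC(=O)Nc1ccc(Cl)cc1` differs from compound 1 in a single place: chloro in place of hydrogen on an aromatic carbon of the anilide ring. Going by the values given here, since compound 1 is known only as a limit, no measured step anchors the size of this change, and the author expects the step that the limit leaves unreadable from compound 1 to compound 3 to be modest, lying within the usual scatter in either direction. Compound 3 is therefore estimated at 1500 nM, with a range from 500 nM to 5000 nM, and a real chance that only a limit is reported again.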

Compound 3, half-maximal inhibitory concentration: > 1000 nM
Compound 3: only a limit was reported; the forecaster's own chance of this, stated with the estimate: 55%; the middle value is on the limit's open side.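

In this assay compound 3 gives > 1000 nM as a limit of the assay and not a number. For the compounds shown here, no step from compound 1 to compound 3 can be read, because both compounds stand at a limit: the limit of > 1000 nM in this assay, at which 2 of the 3 values shown sit. From the compounds shown here alone, what the chloro group on the anilide ring does to inhibition in this assay stays open.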